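The source may report more compounds than this note shows. Statements on the series, on what has been measured and on what is new or still open speak of the compounds shown alone.

In an ADME assay on BJ cells (Homo sapiens) for cytotoxicity, with a stated time of 72 h (on this read-out higher numbers stand for an effect only at larger amounts of compound and lower numbers for an effect already at smaller amounts), compound 1 (`Nc1nc(-c2ccc(Cl)cc2)nn1-c1ncnc2cc(Cl)ccc12`) gives > 47000 nM as a limit of the assay, not a number. For compound 2 (`COc1cc2ncnc(-n3nc(-c4ccccn4)nc3N)c2cc1N`) the entry reads "not determined" (no result reported) and provides no figure. Compound 3 (`COc1cc2ncnc(-n3nc(-c4ccccn4)nc3N)c2cc1OCc1ccccc1`) stands at > 27000 nM which is likewise a limit. Compound 4 (`COc1cc2ncnc(-n3nc(-c4ccccn4)nc3N)c2cc1OCCCN1CC(C)OC(C)C1`) differs from compound 3 (2-(2,6-dimethylmorpholin-4-yl)ethyl in place of phenyl on a saturated chain carbon bound to an oxygen on an aromatic ring) by carrying 2-(2,6-dimethylmorpholin-4-yl)ethyl in place of phenyl on a saturated chain carbon bound to an oxygen on an aromatic ring. Among the measured compounds shown here, no measured step is available for comparison, so no change beyond the usual scatter is expected in this assay in either direction. The expected change is an at least 1.0-fold lower number from compound 3 to compound 4 (0.03 log units; that floor lies within the scatter) and remains only an estimate. For compound 4 the estimated value is 25000 nM with an expected range from 8000 nM to 60000 nM on present evidence.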

Compound 4, half-maximal effective concentration: > 25000 nM
Compound 4: a limit, no number; the forecaster's own chance of this, stated with the estimate: 55%; the middle value lies on the limit itself.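

In this assay, among the compounds shown here, compound 3 and compound 4 both give only a limit, not a number, so no step between them can be read. The compounds shown leave open whether 2-(2,6-dimethylmorpholin-4-yl)ethyl in place of phenyl changes the read-out at all.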